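Azepan-1-yl in place of cyclopentylamino on the sulfonyl chain

This account rests on a few compounds, and the source may have more. Where it says the series, first, only, none or still open, it means among the compounds named here.

In an ADME assay for permeability, using PAMPA (a higher number here means that the compound crosses the layer faster, a lower number that the compound crosses the layer more slowly), compound 1 (`NC(=O)c1cc(-c2ccccc2)cc2c(C3CCN(S(=O)(=O)CCCNC4CCCC4)CC3)c[nH]c12`) gives 140 nm/s and stands lowest of the two measured compounds. Compound 2 (`CC1(C)CC(c2c[nH]c3c(C(N)=O)cc(-c4ccccc4)cc23)CCS1(=O)=O`) gives 330 nm/s as its number, higher than that of compound 1 and beyond the usual scatter. These two differ in more than one place, so their gap is no guide to a single change. Compound 3 (`NC(=O)c1cc(-c2ccccc2)cc2c(C3CCN(S(=O)(=O)CCCN4CCCCCC4)CC3)c[nH]c12`), not yet measured, differs from compound 1 by azepan-1-yl in place of cyclopentylamino on a saturated chain carbon, three bonds along the chain from a sulfonyl sulfur on a saturated chain carbon, three bonds along the chain from a sulfonyl sulfur. For the measured compounds named here, no measured pair covers this change, so the expectation is a cautious one, with no step beyond the scatter. The estimated upward move is a 1.4-fold higher number from compound 1 to compound 3 (0.13 log units; within the scatter) in this assay and remains only an expectation. For compound 3 the expected value is 190 nm/s with an estimated range from 85 nm/s to 420 nm/s until a measurement is available.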

Compound 3, apparent permeability in the ADME assay: 290 nm/s
Beside the measured number, compound 3's estimate is 1.5-fold (0.18 log units) below it; low and high end bracket the measured number.
By their numbers in the ADME assay, from the lowest: compound 1; then compounds 3 and 2 (each within the scatter of the next).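

For the compounds shown here, for the first time, a single change at this position can be read: azepan-1-yl in place of cyclopentylamino on a saturated chain carbon, three bonds along the chain from a sulfonyl sulfur, gives in the ADME assay a 2.1-fold higher number from compound 1 to compound 3 (0.32 log units; beyond the scatter), a modest step, with compound 1 at 140 nm/s and compound 3 at 290 nm/s. In a physicochemical assay for solubility, read by HPLC, measured as kinetic solubility (a higher number here means a more soluble compound, a lower number a less soluble compound), compound 1 gives 85000 nM and compound 3 gives 93000 nM. In the physicochemical assay the same change gives a 1.1-fold higher number from compound 1 to compound 3 (0.04 log units; within the scatter), so the two compounds cannot be told apart there. No evidence on the cause of the step is at hand.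

The change alters the ring and also goes from 1 hydrogen-bond donor to 0 hydrogen-bond donors, so this one pair cannot separate the two. Open, on these data alone, are piperidin-1-yl, a tertiary amine that keeps the cyclopentyl ring, and a longer chain to the sulfonyl sulfur.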